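The compounds below may be only part of what the source reports. "The series", "measured", "known", "first", "only" and "open" are said of these compounds alone.

Of the compounds shown here, two have been measured in a functional assay on Hep 3B2 cells (Homo sapiens) for antiproliferative activity, read by MTT assay, with a stated time of 24 h, tested at 1.23 ug/mL; on this read-out higher numbers stand for a stronger effect at the one concentration tested and lower numbers for a weaker effect. Compound 1 `Cc1c(C(=O)Nc2c(F)cc(-c3cccc(F)c3)cc2F)nc2ccc(C(F)(F)F)cc2c1O` gives 15.3%, and compound 2 `CCOc1ccc2nc(C(=O)Nc3c(F)cc(-c4cccc(F)c4)cc3F)c(C)c(C(=O)O)c2c1` gives 17.9%. The two numbers lie within the scatter of each other, so on the evidence so far neither compound can be set apart from the other; both sit in the range of a modest effect at the single concentration tested.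

Compound 3 `Cc1c(C(=O)Nc2c(F)cc(-c3cccc(F)c3)cc2F)nc2ccc(C(F)(F)F)cc2c1C(=O)O` has not yet been measured. It differs from compound 2 in one place: trifluoromethyl in place of ethoxy on an aromatic carbon. No comparable change between measured compounds is available to show how large a step this brings. Given that both measured compounds sit within the scatter of each other, the step from compound 2 to compound 3 in this assay is expected to be a number 1.9 percentage points lower from compound 2 to compound 3 (within the scatter), which is no change beyond the scatter. Compound 3 is therefore estimated to give 16%, with a range from 5% to 28%.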

Compound 3, a percentage reported as inhibition, at one concentration (the size of the read-out at that concentration, not a potency): 17.2%
For compound 3 the middle estimate is 1.2 percentage points below the measured one; the range from low to high includes it.
By their numbers in this assay, from the lowest: compounds 1, 3 and 2 (each within the scatter of the next).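

In this assay, trifluoromethyl in place of ethoxy on the aromatic carbon gives a number 0.7 percentage points lower from compound 2 to compound 3 (within the scatter), so these two quite different groups cannot be told apart at this position. A second single-place change can also be read now: carboxy in place of hydroxy on an aromatic carbon gives a number 1.9 percentage points higher from compound 1 to compound 3 (within the scatter), so this swap on the shared core does not separate the compounds either. Nothing available explains either result.

These compounds leave open whether any group at the ethoxy and trifluoromethyl position, such as an amine or a longer chain like butoxy, could produce a step beyond the scatter. From the compounds shown here alone, it is also open whether an amide or an amine in place of the carboxy or hydroxy group would do so.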